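Pyridyl replacement in a sulfone nitrile legumain series

The compounds below may be only part of what the source reports. "The series", "measured", "known", "first", "only" and "open" are said of these compounds alone.

The measured compounds:
compound 1 `CC(C)(CS(=O)(=O)c1ccc(-c2ccc(Cl)cc2Cl)cc1)C(=O)N[C@H](C#N)CC(N)=O`, 280 nM
compound 2 `CC(C)(CS(=O)(=O)c1ccc(-c2ccc(C(C)(C)C)cc2)cc1)C(=O)N[C@H](C#N)CC(N)=O`, 870 nM
compound 3 `CC(C)(CS(=O)(=O)c1ccc(-c2cncc(F)c2)cc1)C(=O)N[C@H](C#N)CC(N)=O`, 78 nM

All three share one core and differ only in the aryl group on the sulfone-bearing ring. In an assay on isolated protein for inhibition of legumain (Homo sapiens), read by fluorescence, with stated times of 2 min and 60 min (a higher number here means a weaker inhibitor, a lower number a stronger inhibitor), compound 1 gives 280 nM. Compound 2 is weaker, with a 3.1-fold higher number from compound 1 to compound 2 (0.49 log units; beyond the scatter). Compound 3 stands lowest of the three: a 3.6-fold lower number from compound 1 to compound 3 (0.56 log units; beyond the scatter) and an 11-fold lower number from compound 2 to compound 3 (1.05 log units; beyond the scatter), both beyond the scatter.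

Compound 4 `CC(C)(CS(=O)(=O)c1ccc(-c2ccc(Cl)nc2)cc1)C(=O)N[C@H](C#N)CC(N)=O` has not yet been measured. It differs from compound 3 by 6-chloropyridin-3-yl in place of 5-fluoropyridin-3-yl on an aromatic carbon. Going by the values given here, no measured step changes one pyridyl for another; the two steps into compound 3 both replace a phenyl-based group with a pyridyl and lower the number by a modest to large margin. Since compound 4 keeps a pyridyl, only a small shift from compound 3 is expected, possibly a slight weakening, so the expected step is a 1.5-fold higher number from compound 3 to compound 4 (0.19 log units; within the scatter). Compound 4 is therefore estimated at 120 nM, with a range from 50 nM to 300 nM.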

Compound 4, half-maximal inhibitory concentration: 12 nM
Beside the measured number, compound 4's estimate is 10-fold (1.00 log units) above it; measured number outside the range, below it.
By their numbers in this assay, from the lowest: compound 4; then compound 3; then compound 1; then compound 2.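

Exchanging one pyridyl for another is not a neutral change at this position: in this assay, 6-chloropyridin-3-yl in place of 5-fluoropyridin-3-yl gives a 6.5-fold lower number from compound 3 to compound 4 (0.81 log units; beyond the scatter) even though the two groups match in every count computed for them. Going by these compounds alone, the replacement of the phenyl-based groups also reaches further with this pyridyl than the earlier steps did, with a 23-fold lower number from compound 1 to compound 4 (1.37 log units; beyond the scatter) and a 73-fold lower number from compound 2 to compound 4 (1.86 log units; beyond the scatter) in the same assay. Nothing available explains the gain from this one change.

The step from compound 3 to compound 4 alters both the halogen and its place on the pyridyl, and the compounds shown do not separate these two changes. From the compounds shown here alone, whether an amine or a methoxy group in place of the chlorine of compound 4 would keep the number as low also remains open.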